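This account rests on a few compounds, and the source may have more. Where it says the series, first, only, none or still open, it means among the compounds named here.

Working notes on the series. Two analogues are in hand: compound 1 `Cc1cc(O)cc(-c2nn(CC#N)cc2-c2ccnc(-c3ccc(Oc4ccccc4)cc3)c2)c1` and compound 2 `COc1cc(C)cc(-c2nn(CC#N)cc2-c2ccnc(-c3ccc(N(C)C)cc3)c2)c1`. In a functional assay on NCI/ADR-RES cells (Homo sapiens) for cytotoxicity, read by sulforhodamine B assay, with a stated time of 48 h, tested at 0.001 uM (a lower number here means a stronger effect, a higher number a weaker effect of the compound at the concentration tested), compound 1 gives 105%, and in this assay compound 2 gives 96%. The two readings fall within the scatter of each other, so compound 2 cannot be set apart from compound 1 on these numbers; both sit at essentially full activity, meaning no measurable effect at the concentration tested.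

Compound 3 `Cc1cc(O)cc(-c2nn(CC#N)cc2-c2ccnc(-c3ccc(N(C)C)cc3)c2)c1` is not yet measured. It differs from compound 2 by hydrogen in place of methyl on an oxygen on an aromatic ring, which cut one bond further out reads methoxy to hydroxy, 3-methoxy-5-methylphenyl to 3-hydroxy-5-methylphenyl. Among the measured compounds shown here, no step between measured compounds isolates this change, so there is no measured precedent for it. Given that compound 2 gives 96% in this assay, no step beyond the scatter is expected in either direction. The expected step is a number 4 percentage points higher from compound 2 to compound 3 (within the scatter). Compound 3 is estimated at 100%, with a range from 85% to 115%.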

Compound 3, a percentage reported as activity, at one concentration (the size of the read-out at that concentration, not a potency): 97%
The estimate for compound 3 lay 3 percentage points above the measured number, within the range that was stated.
By their numbers in this assay, from the lowest: compounds 2, 3 and 1 (each within the scatter of the next).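

In this assay, among the compounds shown here, hydrogen in place of methyl on an oxygen on an aromatic ring, methoxy to hydroxy, gives a number 1 percentage points higher from compound 2 to compound 3 (within the scatter) and so does not set the two compounds apart at this concentration; this is the first step that isolates this change. With the 3-hydroxy-5-methylphenyl group held constant, dimethylamino in place of phenoxy on an aromatic carbon gives a number 8 percentage points lower from compound 1 to compound 3 (within the scatter), so these two groups also cannot be told apart in this read-out. Nothing further is available to account for these readings.

The compounds shown leave open whether a longer chain on that oxygen, such as ethoxy or propoxy, would give a step beyond the scatter. As far as these compounds go, it also remains open whether a carboxylic acid or a primary amine in place of dimethylamino would do so.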